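This account rests on a few compounds, and the source may have more. Where it says the series, first, only, none or still open, it means among the compounds named here.

Measured so far:
- compound 1 `CC1(/C=C/c2ccccc2C(F)(F)F)C=CC(=O)O1`: 14100 nM
- compound 2 `CC1(/C=C/c2ccc(C(F)(F)F)cc2)C=CC(=O)O1`: 15700 nM

In a functional assay on U-251 cells (Homo sapiens) for inhibition, read by sulforhodamine B assay, with a stated time of 48 h (on this read-out lower numbers stand for stronger inhibition of growth and higher numbers for weaker inhibition of growth), compound 2 gives 15700 nM, within the scatter of compound 1 at 14100 nM. Compound 3 `CC1(/C=C/c2ccc(O)cc2)C=CC(=O)O1` carries hydroxy in place of trifluoromethyl on an aromatic carbon. Going by the values given here, no measured pair shows what this swap does, so the expectation stays loose: a modest step in this assay toward weaker inhibition of growth, possibly none beyond the scatter. The expected change is a 1.3-fold higher number from compound 2 to compound 3 (0.11 log units; within the scatter). For compound 3 the estimated value is 20000 nM, with an expected range from 9000 nM to 45000 nM.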

Compound 3, concentration for total growth inhibition: 107000 nM
For compound 3 the middle estimate is 5.4-fold (0.73 log units) below the measured one; the whole stated range lies below it.
By their numbers in this assay, from the lowest: compounds 1 and 2 (each within the scatter of the next); then compound 3.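

The aromatic carbon para to a group of 9 heavy atoms proves sensitive to what it carries: in this assay, hydroxy in place of trifluoromethyl gives a 6.8-fold higher number from compound 2 to compound 3 (0.83 log units; beyond the scatter) and so lies beyond the scatter, a separation that compounds 1 and 2 did not show. Nothing available explains this step. The compounds shown leave open whether a methoxy or an amine on this carbon would fall nearer compound 2 or compound 3. They also leave open whether hydroxy in place of the trifluoromethyl of compound 1 would give a similar step.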